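The compounds below may be only part of what the source reports. "The series", "measured", "known", "first", "only" and "open" are said of these compounds alone.

Compound 1 `COc1ccc(C[C@H]2COC(=O)[C@@H]2Cc2ccc(OCc3cn(Cc4ccccc4F)nn3)c(OC)c2)cc1OC`, compound 2 `COC(=O)[C@@H](NC(=O)CCC(=O)Oc1ccc(C[C@H]2C(=O)OC[C@@H]2Cc2ccc(OC)c(OC)c2)cc1OC)C(C)C` and compound 3 `COC(=O)[C@H](CC(C)C)NC(=O)CCC(=O)Oc1ccc(C[C@H]2C(=O)OC[C@@H]2Cc2ccc(OC)c(OC)c2)cc1OC` were tested in an ADME assay on HeLa cells (Homo sapiens) for cytotoxicity, read by MTT assay; on this read-out lower numbers stand for stronger inhibition and higher numbers for weaker inhibition. Compound 1 gives >= 600000 nM, which is a limit of the assay rather than a number. Compound 2 gives 64000 nM. Among the measured compounds shown here, compound 3 gives 53200 nM, and the step of a 1.2-fold lower number from compound 2 to compound 3 (0.08 log units; within the scatter) is the only measured step in this set. Compound 1 therefore stands at the limit of >= 600000 nM in this assay, at which 1 of the 3 values shown sits, with no number of its own among the three compounds.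

Compound 4 `COc1ccc(C[C@H]2COC(=O)[C@@H]2Cc2ccc(OCc3cn(-c4ccc(Cl)cc4)nn3)c(OC)c2)cc1OC` differs from compound 1 by 4-chlorophenyl in place of 2-fluorobenzyl on an aromatic nitrogen. No measured step touches this part of the shared core, and the one measured step lies within the scatter, so nothing shown points to a change beyond the scatter. Compound 4 is therefore expected near 600000 nM, within 250000 nM to 1500000 nM. That amounts to an expected step of a number no higher from compound 1 to compound 4 (the limit leaves the size open).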

Compound 4, half-maximal inhibitory concentration: 279000 nM
Compound 4: the middle estimate sits 2.2-fold (0.33 log units) above what was measured; the measured number falls inside the stated range.
By their numbers in this assay, from the lowest: compounds 3 and 2 (each within the scatter of the next); then compound 4. At a limit, above all of these: compound 1.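

In this assay, the change on the aromatic nitrogen gives a step beyond the scatter: an at least 2.1-fold lower number from compound 1 to compound 4 (0.33 log units; beyond the scatter). Among the compounds shown here, this is the first sign that the group at this position can shift the read-out, as the only earlier step lay elsewhere and stayed within the scatter. The full size of the step stays open, as compound 1 sits at a limit of the assay, not at a number: the limit of >= 600000 nM in this assay, at which 1 of the 4 values shown sits.

The swap changes both the halogen and the benzyl-to-phenyl attachment, so the compounds shown leave open which of the two matters. A 4-chlorobenzyl group on the same nitrogen would help separate them.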